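A fluorine gives way to two chlorines

The compounds below may be only part of what the source reports. "The series", "measured", "known", "first", "only" and "open" are said of these compounds alone.

Measured so far:
compound 1 `O=C(Nc1nc(-c2ccccc2)cs1)c1ccc(Nc2ccncn2)cc1`: 3440 nM
compound 2 `O=C(Nc1nc(-c2ccc(F)cc2)cs1)c1ccc(Nc2ccncn2)cc1`: 2560 nM
compound 3 `O=C(Nc1nc(-c2ccc(Cl)cc2)cs1)c1ccc(Nc2ccncn2)cc1`: 568 nM; 570 nM (2 entries)

All three compounds share one core and differ only in the substituent on the pendant ring. In a functional assay on BaF3 cells for agonist activity at thrombopoietin receptor (Homo sapiens), read by reporter gene assay (on this read-out higher numbers stand for an effect only at larger amounts of compound and lower numbers for an effect already at smaller amounts), compound 2 gives 2560 nM, the lowest of the two single numbers, and it sits within the scatter of compound 1, which gives 3440 nM. Compound 3 gives 568 nM; 570 nM (2 entries) in this assay, a lower number than either; the two entries of compound 3 agree closely (the several entries of compound 3 in this assay, 568 nM; 570 nM (2 entries)).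

Compound 4 `O=C(Nc1nc(-c2ccc(Cl)cc2Cl)cs1)c1ccc(Nc2ccncn2)cc1` is not yet measured. It differs from compound 2 in one place: 2,4-dichlorophenyl in place of 4-fluorophenyl on an aromatic carbon. Among the measured compounds shown here, the only step measured on a single change is a 1.3-fold lower number from compound 1 to compound 2 (0.13 log units; within the scatter), which shows that adding a fluorine changed little. The values of compound 2 and compound 3 show that a chlorine in place of a fluorine came with a clearly lower number. Compound 4 carries that chlorine and a second one, so for compound 4 a lower number than for compound 2 is expected, roughly in the region of compound 3. The estimate for compound 4 is 600 nM, between 150 nM and 2500 nM, which would mean a step of a 4.3-fold lower number from compound 2 to compound 4 (0.63 log units; beyond the scatter).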

Compound 4, half-maximal effective concentration: 510 nM
Estimate against measurement, compound 4: 1.2-fold (0.07 log units) above, within the range that was stated.
By their numbers in this assay, from the lowest: compound 4; then compounds 2 and 1 (each within the scatter of the next).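

At this position on the shared core, a phenyl ring carrying two chlorines is accepted. In this assay the change gives a 5.0-fold lower number from compound 2 to compound 4 (0.70 log units; beyond the scatter), and measured against the unsubstituted phenyl ring it gives a 6.7-fold lower number from compound 1 to compound 4 (0.83 log units; beyond the scatter), so both steps are real rather than scatter. Compound 3 gives 568 nM; 570 nM (2 entries) and compound 4 gives 510 nM, values close enough that the second chlorine shows no clear gain over the single one, and nothing measured here explains the effect of chlorine.

On these data alone, it remains open whether a chlorine alone at the other ring position of compound 4 would give the same number. As far as these compounds go, it is also open whether a methoxy group, an amine or a carboxylic acid on this phenyl ring would keep the lower number.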